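Lengthening the Chloroalkyl Chain of an Inactive Amide

A few compounds are considered here, and "the series" means these few. Any claim that something is new, unique, unknown or untested is made for them only; others in the source may bear on it.

Compound 1 `CC(C)(C)c1ccc(CNC(=O)NC(=O)CCl)cc1` gives 2400 nM in a functional assay on M21 cells (Homo sapiens) for antiproliferative activity, with a stated time of 48 h; on this read-out lower numbers stand for stronger inhibition and higher numbers for weaker inhibition.
Compound 2 `CCNC(=O)NCc1ccc(C(C)(C)C)cc1` reaches only a limit of this assay, > 100000 nM.
Compound 3 `CC(C)(C)c1ccc(CNC(=O)CCCl)cc1` likewise sits at a limit, > 100000 nM.

Compound 3 thus stands at the limit of > 100000 nM in this assay, at which 2 of the 3 values shown sit, with no number to read. Compound 4 `CC(C)(C)c1ccc(CNC(=O)CCCCl)cc1` differs from it by chloromethyl in place of chloro on a saturated chain carbon, two bonds along the chain from a carbonyl carbon. Among the measured compounds shown here, no measured step alters this chain; the nearest comparisons are an at least 41-fold higher number from compound 1 to compound 3 (1.61 log units; beyond the scatter) and an at least 41-fold higher number from compound 1 to compound 2 (1.61 log units; beyond the scatter), both large and both ending at a limit, while a step that the two limits leave unreadable from compound 2 to compound 3 cannot be read. Starting from a limit, this extension is expected to leave compound 4 near 100000 nM, most likely again only a limit, within 30000 nM to 300000 nM. The step of a number no higher from compound 3 to compound 4 (the limit leaves the size open) is therefore expected to be none beyond the scatter.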

Compound 4, half-maximal inhibitory concentration: 69000 nM
Compound 4: the middle estimate sits 1.4-fold (0.16 log units) above what was measured; measured number inside the range.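

Compound 4 gives a number rather than a limit in this assay: 69000 nM. Lengthening the chain brings only an at least 1.4-fold lower number from compound 3 to compound 4 (0.16 log units; that floor lies within the scatter), and 3-chloropropyl in place of ethylamino brings an at least 1.4-fold lower number from compound 2 to compound 4 (0.16 log units; that floor lies within the scatter), so neither change is shown to do more than repeated measurement could. The 3-chloropropyl group also stays far from the ((chloromethyl)carbonyl)amino group, with a 29-fold higher number from compound 1 to compound 4 (1.46 log units; beyond the scatter).

The true size of the first two steps stays open: the limit of > 100000 nM in this assay, at which 2 of the 4 values shown sit.
Going by these compounds, whether a longer chain, or an amine in place of the chloro, would move the number also remains open.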